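The source may report more compounds than this note shows. Statements on the series, on what has been measured and on what is new or still open speak of the compounds shown alone.

Of the compounds shown here, two have been measured in an assay on PEO1 cells for inhibition of Retinaldehyde dehydrogenase 3 (Homo sapiens), read by flow cytometry, with a stated time of 30 min, tested at 1 uM; a higher number here means more inhibition at the concentration tested (going by the name of the read-out), a lower number less inhibition. Compound 1 `CC(Sc1nc2c(cnn2C)c(=O)n1-c1ccccc1)c1ccccn1` gives 97% in this assay, and compound 2 `CC(Sc1nc2nn(C3(C)COC3)cc2c(=O)n1-c1ccccc1)c1ccccc1` gives 90%. These two numbers lie within the usual scatter of each other, so neither compound can be placed above the other; both simply show strong inhibition at the tested concentration.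

Compound 3 `Cn1ncc2c(=O)n(-c3ccccc3)c(SCc3cccc(F)c3)nc21` has not yet been measured in this assay. It differs from compound 1 in one place: 3-fluorobenzyl in place of 1-(pyridin-2-yl)ethyl on a sulfur. Among the compounds with values here, no pair of measured compounds shows the effect of a change of this kind, so there is no measured step to lean on. Because compound 1 reaches 97% and compound 2 stays near it at 90%, the expected step is a number 9 percentage points lower from compound 1 to compound 3 (within the scatter). Compound 3 is therefore estimated at 88%, with a plausible range from 68% to 98%.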

Compound 3, a percentage reported as inhibition, at one concentration (the size of the read-out at that concentration, not a potency): 3%
Estimate against measurement, compound 3: 85 percentage points above, and the stated range ends above it.
By their numbers in this assay, from the lowest: compound 3; then compounds 2 and 1 (each within the scatter of the next).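

The group on the sulfur turns out to matter greatly in this assay: putting 3-fluorobenzyl in place of 1-(pyridin-2-yl)ethyl gives a number 94 percentage points lower from compound 1 to compound 3 (beyond the scatter), with the rest of the molecule unchanged. The shared core therefore does not bring strong inhibition on its own, since compound 3 reaches only 3% at the tested concentration. No measurement at hand gives a reason for this drop.

The change alters several things at once, as a ring nitrogen leaves, a fluorine enters and the 1-(pyridin-2-yl)ethyl group gives way to a benzyl, so the compounds shown do not say which of these counts. They also leave open how other groups on the sulfur, such as a plain benzyl or a longer chain ending in an amine, would behave.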